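Truncating the cyclohexyl substituent in a fluoro-bromoanilino oxime series

The compounds below may be only part of what the source reports. "The series", "measured", "known", "first", "only" and "open" are said of these compounds alone.

Within the data shown here, compound 1 `NS(=O)(=O)NC[C@H]1CC[C@H](C(=O)/C(=N/O)Nc2ccc(F)c(Br)c2)CC1` carries the lower of the two numbers measured so far in an assay for inhibition of Tryptophan 2,3-dioxygenase (Homo sapiens), with a stated time of 1 h (on this read-out lower numbers stand for stronger inhibition and higher numbers for weaker inhibition), where compound 1 gives 58700 nM. Compound 2 `O=C(/C(=N/O)Nc1ccc(F)c(Br)c1)C1CCN(S(=O)(=O)Nc2ccccc2)CC1` gives 65700 nM in this assay, a gap within the scatter, so no order between compound 1 and compound 2 is claimed. Compound 3 `O=C(/C(=N/O)Nc1ccc(F)c(Br)c1)C1CCCCC1` awaits measurement. It differs from compound 1 by hydrogen in place of (sulfamoylamino)methyl on a saturated ring carbon. Among the measured compounds shown here, no measured pair covers a change of this kind. For compound 3 the expected step in this assay is a 1.3-fold higher number from compound 1 to compound 3 (0.11 log units; within the scatter), modest and toward a higher number. Compound 3 is estimated at 75000 nM, ranging from 25000 nM to 220000 nM.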

Compound 3, half-maximal inhibitory concentration: 79300 nM
Estimate against measurement, compound 3: 1.1-fold (0.02 log units) below, within the range that was stated.
By their numbers in this assay, from the lowest: compounds 1, 2 and 3 (each within the scatter of the next).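

Replacing the (sulfamoylamino)methyl with hydrogen gives a 1.4-fold higher number from compound 1 to compound 3 (0.13 log units; within the scatter) in this assay and so yields the first step read at this position. The large group on the saturated ring carbon can leave without a change beyond the scatter, so neither this group nor its hydrogen-bond donors and acceptors are shown to matter in this assay. No other data bear on this result.

From the compounds shown here alone, whether an amine, a carboxylic acid or a longer chain on this ring carbon would move the number beyond the scatter remains open. So does whether any change at this position can do so on the shared core.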